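A few compounds are considered here, and "the series" means these few. Any claim that something is new, unique, unknown or untested is made for them only; others in the source may bear on it.

Measured so far:
Compound 1 `COc1n[nH]c2ncc(C#Cc3c(F)ccc(NS(=O)(=O)c4ccccc4Cl)c3F)cc12` — 5.1 nM
Compound 2 `COc1n[nH]c2ncc(C#Cc3c(F)ccc(NS(=O)(=O)c4ccc(Cl)cc4)c3F)cc12` — 16.8 nM
Compound 3 `COc1n[nH]c2ncc(C#Cc3c(F)ccc(NS(=O)(=O)c4cccc(C)c4)c3F)cc12` — 12.1 nM

All three share one core and differ only in the ring attached to the sulfonyl sulfur. In an assay on cells for inhibition of mitogen-activated protein kinase kinase kinase 20 (Homo sapiens), read by ADP-Glo, with a stated time of 30 min (a higher number here means a weaker inhibitor, a lower number a stronger inhibitor), compound 1 gives 5.1 nM, and compound 3 sits second highest of the three numbers. Its nearest neighbour is compound 2, which lies within the scatter of it, as the step of a 1.4-fold lower number from compound 2 to compound 3 (0.14 log units; within the scatter) shows. Compound 1 is further off: the step of a 2.4-fold higher number from compound 1 to compound 3 (0.38 log units; beyond the scatter) is beyond the scatter, as is a 3.3-fold higher number from compound 1 to compound 2 (0.52 log units; beyond the scatter).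

Compound 4 `COc1n[nH]c2ncc(C#Cc3c(F)ccc(NS(=O)(=O)c4cccc(Br)c4)c3F)cc12` differs from compound 3 by a single swap: bromo in place of methyl on an aromatic carbon. For the measured compounds named here, no measured step changes one group for another at this same place on the ring; the steps that were measured move a group to another place or exchange chloro for methyl, and of these only a 1.4-fold lower number from compound 2 to compound 3 (0.14 log units; within the scatter) stays within the scatter. On that thin basis only a small step, if any, is expected, a 1.2-fold lower number from compound 3 to compound 4 (0.08 log units; within the scatter). Compound 4 is therefore expected to give about 10 nM in this assay, with a range from 4 nM to 25 nM.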

Compound 4, half-maximal inhibitory concentration: 5 nM
For compound 4 the middle estimate is 2.0-fold (0.30 log units) above the measured one; low and high end bracket the measured number.
By their numbers in this assay, from the lowest: compounds 4 and 1 (each within the scatter of the next); then compounds 3 and 2 (each within the scatter of the next).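

In this assay, swapping one single-atom group for another at this place on the ring, meta to a large group, gives a 2.4-fold lower number from compound 3 to compound 4 (0.38 log units; beyond the scatter), so the choice of group here affects the number even though the heavy-atom count stays the same. The 3-bromophenyl ring also closes the gap to the 2-chlorophenyl ring, with a 1.0-fold lower number from compound 1 to compound 4 (0.01 log units; within the scatter), while a 3.4-fold lower number from compound 2 to compound 4 (0.53 log units; beyond the scatter) shows that the 4-chlorophenyl ring stays apart, so carrying a halogen on this ring does not alone give the lower number. Nothing available explains why bromo and methyl differ here.

Going by these compounds, it remains open how an amine, a nitrile or a carboxylic acid would behave at this same place. On these data alone, the effect of bromo at the other places on the ring also remains unknown.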